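Replacing a diol with an ethylsulfonyl on the shared core

The source may hold more compounds than are shown below. What is called first, only, known or untested is meant among the compounds shown, and "the series" means these compounds.

Compound 1 `N#Cc1ccc(Nc2nccc(N(c3c(F)cc(-c4ccc(C#N)cc4)cc3F)C3CCCC3)n2)cc1` gives 232000 nM in an ADME assay on MT4 cells (Homo sapiens) for cytotoxicity, read by MTT assay, with a stated time of 5 days; on this read-out higher numbers stand for lower toxicity in this test and lower numbers for higher toxicity in this test.
Compound 2 `N#Cc1ccc(Nc2nccc(N(CC3CCCC3)c3c(F)cc(-c4ccc(C#N)cc4)cc3F)n2)cc1` gives > 247000 nM in this assay; that value is a limit of the assay, not a number.
Compound 3 `N#Cc1ccc(Nc2nccc(N(CC(O)CO)c3c(F)cc(-c4ccc(C#N)cc4)cc3F)n2)cc1` gives 19500 nM in this assay.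

Compound 3 stands at the lowest of the two numbers in this assay; the nearest number belongs to compound 1, and the step of a 12-fold lower number from compound 1 to compound 3 (1.08 log units; beyond the scatter) is large. The step of an at least 12-fold lower number from compound 2 to compound 3 (1.10 log units; beyond the scatter) runs the same way, measured against a limit (the limit of > 247000 nM in this assay, at which 1 of the 3 values shown sits). The step of an at least 1.0-fold higher number from compound 1 to compound 2 (0.02 log units; that floor lies within the scatter) stays within the scatter. Compound 4 `CCS(=O)(=O)N(c1ccnc(Nc2ccc(C#N)cc2)n1)c1c(F)cc(-c2ccc(C#N)cc2)cc1F` has not yet been measured. It differs from compound 3 in one place: ethylsulfonyl in place of 2,3-dihydroxypropyl on a nitrogen on an aromatic ring. Both measured steps that reach compound 3 show that the 2,3-dihydroxypropyl group goes with a markedly lower number than either hydrocarbon group. Going by the values given here, no measured compound carries an ethylsulfonyl, so only the loss of the diol can be weighed. The number for compound 4 is therefore expected to rise again, by a step estimated at a 5.1-fold higher number from compound 3 to compound 4 (0.71 log units; beyond the scatter), though probably not all the way to where compound 1 and compound 2 sit. The estimate for compound 4 is 100000 nM, with a range from 30000 nM to 250000 nM.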

Compound 4, half-maximal cytotoxic concentration: > 125000 nM
Compound 4: only a limit was reported; the forecaster's own chance of this, stated with the estimate: 35%; at least 1.2-fold (0.09 log units) between middle value and limit.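

In this assay, compound 4 gives > 125000 nM, which is a limit of the assay and not a number. Going by these compounds alone, putting ethylsulfonyl on this nitrogen in place of 2,3-dihydroxypropyl gives an at least 6.4-fold higher number from compound 3 to compound 4 (0.80 log units; beyond the scatter), so a group with the same counts of heavy atoms and hydrogen-bond acceptors, but with no hydrogen-bond donors, does not share the low number of compound 3, and at this position the low number no longer separates the diol only from hydrocarbon groups, as it did among the earlier compounds. The steps linking compound 4 to compound 1 and compound 2 cannot be read, because limits stand in place of numbers, as here: the limit of > 125000 nM in this assay, at which 1 of the 4 values shown sits.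

From the compounds shown here alone, what remains open is whether the low number of compound 3 goes with its two hydroxyl groups or with the diol chain as a whole, which a group carrying a single hydroxyl, such as 2-hydroxyethyl, could help to separate. Going by these compounds, how an amine or a carboxylic acid on this nitrogen would read in this assay also stays unknown, as does whether any of these groups would bring the number down as far as the diol does.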